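The source may hold more compounds than are shown below. What is called first, only, known or untested is meant among the compounds shown, and "the series" means these compounds.

In a functional assay on MDA-MB-231 cells (Homo sapiens) for inhibition, read by CCK-8 assay, with a stated time of 48 h (on this read-out lower numbers stand for stronger inhibition of growth and higher numbers for weaker inhibition of growth), compound 1 `Cc1ccccc1Nc1nc(Nc2cccnc2)ncc1Cl` gives 41200 nM and compound 2 `Cc1ccccc1Nc1nc(Nc2ccccn2)ncc1Cl` gives 11200 nM. Compound 3 `CN1CCN(c2ccc(Nc3ncc(Cl)c(NCc4ccccc4)n3)nc2)CC1` gives 24800 nM, which lies within the scatter of compound 1 and above compound 2 by more than the scatter. Compound 4 `COc1ccccc1CNc1nc(Nc2ccc(N3CCN(C)CC3)cn2)ncc1Cl` differs from compound 3 by methoxy in place of hydrogen on an aromatic carbon, on a six-membered aromatic ring of carbon only, ortho to a large group. Within the data shown here, the only measured step, a 3.7-fold lower number from compound 1 to compound 2 (0.57 log units; beyond the scatter), is modest and concerns a different change, pyridin-2-yl in place of pyridin-3-yl. Among the measured compounds shown here, no measured step covers methoxy in place of hydrogen, so no shift beyond the scatter is expected in this assay. The estimated step is a 1.2-fold lower number from compound 3 to compound 4 (0.09 log units; within the scatter). For compound 4 the estimate is 20000 nM, with an expected range of 9000 nM to 45000 nM.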

Compound 4, concentration for 50% growth inhibition: 29300 nM
Compound 4: the middle estimate sits 1.5-fold (0.17 log units) below what was measured; low and high end bracket the measured number.
By their numbers in this assay, from the lowest: compound 2; then compounds 3, 4 and 1 (each within the scatter of the next).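

In this assay the change from benzyl to 2-methoxybenzyl amounts to a 1.2-fold higher number from compound 3 to compound 4 (0.07 log units; within the scatter) and so gives the series its first read on this ring: methoxy on this aromatic carbon, ortho to a large group, brings no shift that can be told from the scatter. The evidence at hand offers no explanation for this flat step. Still open, going by these compounds, is whether an amine, a carboxylic acid or a longer alkoxy chain on this carbon would move the number, and whether methoxy on another carbon of this ring would do so.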